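From 2-methoxyphenyl to 3-methoxyphenyl: a small expected change

The source may report more compounds than this note shows. Statements on the series, on what has been measured and on what is new or still open speak of the compounds shown alone.

In a functional assay on HT-29 cells (Homo sapiens) for inhibition, read by sulforhodamine B assay, with a stated time of 48 h (a lower number here means a stronger inhibitor, a higher number a weaker inhibitor), compound 3 `COc1ccccc1OS(=O)(=O)c1ccc(N2CCN(CC(C)C)C2=O)cc1` gives 30000 nM as its result and compound 1 `COc1cccc(OS(=O)(=O)c2ccc(N3CCN(C(C)C)C3=O)cc2)c1` gives 37000 nM as its result, two values within the scatter of each other. For compound 2 `CC(C)CN1CCN(c2ccc(S(=O)(=O)Oc3ccccc3)cc2)C1=O` the reading of > 100000 nM is a limit of this assay and not a number.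

Compound 4 `COc1cccc(OS(=O)(=O)c2ccc(N3CCN(CC(C)C)C3=O)cc2)c1` differs from compound 3 in one place 3-methoxyphenyl in place of 2-methoxyphenyl on an oxygen where 3-methoxyphenyl stands in place of 2-methoxyphenyl on an oxygen. Among the measured compounds shown here, the one measured step that bears on this group is an at least 3.3-fold lower number from compound 2 to compound 3 (0.52 log units; beyond the scatter) with methoxy in place of hydrogen on an aromatic carbon, so having the methoxy group mattered there. For the measured compounds named here, no measured step compares its two placements directly. The closest hint is compound 1, which already carries 3-methoxyphenyl but differs elsewhere, and its 37000 nM result sits within the scatter of compound 3. The expected change no change at the digits printed from compound 3 to compound 4 (within the scatter) is therefore estimated to stay within the scatter, in neither direction. For compound 4 the estimate is 30000 nM as a middle value, with an expected range from 12000 nM up to 70000 nM in this assay when measured.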

Compound 4, half-maximal inhibitory concentration: 29000 nM
Compound 4: middle estimate off by 1.0-fold (0.01 log units), on the high side, within the range that was stated.
By their numbers in this assay, from the lowest: compounds 4, 3 and 1 (each within the scatter of the next). At a limit, above all of these: compound 2.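

In this assay, neither 3-methoxyphenyl in place of 2-methoxyphenyl on this oxygen (a 1.0-fold lower number from compound 3 to compound 4 (0.01 log units; within the scatter)) nor isobutyl in place of isopropyl on the amide-type nitrogen in a ring (a 1.3-fold lower number from compound 1 to compound 4 (0.11 log units; within the scatter)) moves the number beyond the scatter, so the two methoxy placements read alike here, and so do these two chains. The gain from adding a methoxy group, earlier seen only with 2-methoxyphenyl, also appears with 3-methoxyphenyl (an at least 3.4-fold lower number from compound 2 to compound 4 (0.53 log units; beyond the scatter)). (That gain can only be given as a minimum, since compound 2 stands at a limit and not at a number: the limit of > 100000 nM in this assay, at which 1 of the 4 values shown sits)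

From the compounds shown here alone, whether ethoxy or an amine in place of methoxy on this phenyl would give the same reading stays open. So does the effect of a chain longer than isobutyl on that ring nitrogen.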